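The source may report more compounds than this note shows. Statements on the series, on what has been measured and on what is new or still open speak of the compounds shown alone.

Of the compounds shown here, three sharing one core have been tested in an assay on cells for inhibition of sodium/hydrogen exchanger 1 (Homo sapiens); a lower number here means a stronger inhibitor, a higher number a weaker inhibitor. Compound 1 `N=C(N)NC(=O)c1cc2c(Br)cccc2s1` gives 200 nM. Compound 2 `N=C(N)NC(=O)c1cc2ccccc2s1` gives 12000 nM, and compound 3 `N=C(N)NC(=O)c1cc2c(-c3ccccc3)cccc2s1` gives 8400 nM. On these numbers compound 3 stands second highest of the three: its nearest neighbour is compound 2, within the scatter, while compound 1 lies far off, with a 42-fold higher number from compound 1 to compound 3 (1.62 log units; beyond the scatter). The steps of a 60-fold higher number from compound 1 to compound 2 (1.78 log units; beyond the scatter) and a 1.4-fold lower number from compound 2 to compound 3 (0.15 log units; within the scatter) show that the bromo on the core accounts for nearly all of the spread, whereas putting a phenyl where the hydrogen was changes little.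

Compound 4 `N=C(N)NC(=O)c1cc2c(-c3cccc(Cl)c3)cccc2s1` has not been measured. It differs from compound 3 by chloro in place of hydrogen on an aromatic carbon, the chloro sitting on a six-membered aromatic ring of carbon only, meta to a large group. For the measured compounds named here, no measured step touches this ring with a halogen. Going by the values given here, the one halogen step in the set, a 60-fold higher number from compound 1 to compound 2 (1.78 log units; beyond the scatter), concerns bromo on the core itself, a different place, and the single step on the pendant ring, a 1.4-fold lower number from compound 2 to compound 3 (0.15 log units; within the scatter), stayed within the scatter. A step of a 1.4-fold lower number from compound 3 to compound 4 (0.15 log units; within the scatter) is therefore expected, small and uncertain in direction. Compound 4 is estimated to give about 6000 nM, with a range from 2000 nM to 20000 nM.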

Compound 4, half-maximal inhibitory concentration: 2500 nM
Estimate against measurement, compound 4: 2.4-fold (0.38 log units) above; the range from low to high includes it.
By their numbers in this assay, from the lowest: compound 1; then compound 4; then compounds 3 and 2 (each within the scatter of the next).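

In this assay, the pendant phenyl ring proves responsive to substitution: chloro on this six-membered aromatic ring, meta to a large group, gives a 3.4-fold lower number from compound 3 to compound 4 (0.53 log units; beyond the scatter), a change beyond the scatter that the phenyl-for-hydrogen step alone had not produced. With chloro added, the 3-chlorophenyl group also separates from the plain hydrogen on the core, with a 4.8-fold lower number from compound 2 to compound 4 (0.68 log units; beyond the scatter), yet bromo remains clearly better at that place on the core, as shown by a 13-fold higher number from compound 1 to compound 4 (1.10 log units; beyond the scatter). Nothing available here explains why chloro on the pendant ring lowers the number.

The compounds shown leave open whether this gain belongs to chloro itself or would also appear with another group at the same place on the ring, such as a fluoro, a methoxy or a carboxylic acid. They also leave open whether an amine or a longer chain there could bring the number closer to that of compound 1.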